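Swapping an aryl amide for cycloheptyl: cytotoxicity outlook

The source may hold more compounds than are shown below. What is called first, only, known or untested is meant among the compounds shown, and "the series" means these compounds.

Measured in an ADME assay on MT2 cells (Homo sapiens) for cytotoxicity, read by XTT assay, with a stated time of 4 days; on this read-out higher numbers stand for lower toxicity in this test and lower numbers for higher toxicity in this test:
compound 1 `Cc1nc(C(NC(=O)C(=O)Nc2ccc(F)c(F)c2)C2CCCCN2)sc1CO` gives > 87000 nM.
compound 2 `Cc1nc(C(NC(=O)C(=O)Nc2ccc(F)cc2)C2CCCCN2)sc1CCO` gives 109000 nM.
compound 3 `CC(=O)N1CCCCC1C(NC(=O)C(=O)Nc1ccc(Cl)cc1)c1nc(C)c(CCO)s1` gives > 84000 nM.

For compound 1 the value in this assay is a limit of the assay, not a number. Compound 3 likewise reaches only a limit in this assay. For the measured compounds named here, compound 2 is the one compound with a number, and that number lies close to where the two limits sit. Compound 1 therefore stands at a limit, with nothing among the three values suggesting any measurable toxicity in this set.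

Compound 4 `Cc1nc(C(NC(=O)C(=O)NC2CCCCCC2)C2CCCCN2)sc1CO` differs from compound 1 by cycloheptyl in place of 3,4-difluorophenyl on an amide-type nitrogen. Going by the values given here, with no measured pair showing this kind of change, any expectation can rest only on the three values above, all of which sit at or near the upper reach of the assay. The step that the limit leaves unreadable from compound 1 to compound 4 is therefore expected to be none beyond the scatter, most likely another limit because compound 1 itself sits at the limit of > 87000 nM in this assay, at which 1 of the 3 values shown sits. Compound 4 is expected to give 90000 nM in this assay, within a range of 40000 nM to 200000 nM.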

Compound 4, half-maximal cytotoxic concentration: > 90000 nM
Compound 4 ended at the assay's limit; the forecaster's own chance of this, stated with the estimate: 70%; the middle value lies on the limit itself.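

In this assay compound 4 gives > 90000 nM, which is a limit of the assay. Compound 1 gives > 87000 nM, also a limit. No step can be read between compound 1 and compound 4. The compounds shown leave open how cycloheptyl and 3,4-difluorophenyl on this amide-type nitrogen compare in this assay.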